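Acetyl to dimethylamino: expectation for compound 3

A few compounds are considered here, and "the series" means these few. Any claim that something is new, unique, unknown or untested is made for them only; others in the source may bear on it.

compound 1 `COc1cc(C)cc(-c2c(-c3ccnc(-c4ccc(C(C)=O)cc4)c3)cnn2CC#N)c1`: > 100000 nM
compound 2 `COc1cc(C)cc(-c2nn(CC#N)cc2-c2ccc(-c3cccc(C(C)=O)c3)nc2)c1`: > 100000 nM

In a functional assay on HOP-62 cells (Homo sapiens) for inhibition, read by sulforhodamine B assay, with a stated time of 48 h (on this read-out higher numbers stand for lower toxicity in this test and lower numbers for higher toxicity in this test), compound 1 gives > 100000 nM, which is a limit of the assay and not a number. Compound 2 gives > 100000 nM, likewise a limit. Where compound 1 stands is thus (the limit of > 100000 nM in this assay, at which 2 of the 2 values shown sit). Among the measured compounds shown here, no measured step between two numbered compounds exists in this set, so no size of change has been recorded for any pair, and no direction can be read from the values shown.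

Compound 3 `COc1cc(C)cc(-c2c(-c3ccnc(-c4ccc(N(C)C)cc4)c3)cnn2CC#N)c1` has not yet been run in this assay. It differs from compound 1 by dimethylamino in place of acetyl on an aromatic carbon. With both shown values sitting at the limit, the series offers no measured step to lean on. The expected step is a number no higher from compound 1 to compound 3 (the limit leaves the size open), none beyond the scatter. Compound 3 is estimated at 100000 nM, with a range from 30000 nM to 300000 nM, and it is expected most likely to be reported again only as a limit.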

Compound 3, concentration lethal to 50% of the cells: > 100000 nM
Compound 3 gave a limit, no number; the forecaster's own chance of this, stated with the estimate: 70%; the middle value lies on the limit itself.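

In this assay compound 3 gives > 100000 nM, a limit of the assay and not a number. Among the compounds shown here, compound 1 is also reported only as a limit, so no step between compound 1 and compound 3 can be read. The compounds shown leave open whether 4-acetylphenyl and 4-(dimethylamino)phenyl differ at all in this assay: the limit of > 100000 nM in this assay, at which 3 of the 3 values shown sit.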